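Amide substituent variation on the shared core, antiproliferative read-out

A few compounds are considered here, and "the series" means these few. Any claim that something is new, unique, unknown or untested is made for them only; others in the source may bear on it.

Measured so far, in a functional assay on MCF7 cells (Homo sapiens) for antiproliferative activity, read by MTT assay, with a stated time of 24 h; on this read-out lower numbers stand for stronger inhibition and higher numbers for weaker inhibition:
compound 1 `CCn1c(C(=O)NC(C)(C)CO)ccc1C(CC)(CC)c1ccc(OCS(=O)(=O)c2ccccc2)c(C)c1` gives 20700 nM
compound 2 `CCn1c(C(=O)N[C@H](CO)C(C)C)ccc1C(CC)(CC)c1ccc(OCS(=O)(=O)c2ccccc2)c(C)c1` gives 25500 nM
compound 3 `CCn1c(C(=O)N[C@@H](C)C(=O)O)ccc1C(CC)(CC)c1ccc(OCS(=O)(=O)c2ccccc2)c(C)c1` gives 35500 nM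

Compound 2 stands second highest of the three numbers; its nearest neighbour is compound 1 with a 1.2-fold higher number from compound 1 to compound 2 (0.09 log units; within the scatter), its furthest compound 3 with a 1.4-fold higher number from compound 2 to compound 3 (0.14 log units; within the scatter), both within the scatter. The whole set therefore sits together in this assay.

Compound 4 `CCn1c(C(=O)N[C@@H](CC(=O)O)C(=O)O)ccc1C(CC)(CC)c1ccc(OCS(=O)(=O)c2ccccc2)c(C)c1` is not yet measured. It differs from compound 2 as follows: 1,2-dicarboxyethyl in place of 1-(hydroxymethyl)-2-methylpropyl on an amide-type nitrogen

Going by the values given here, two measured steps bear on this change, since each puts a carboxy-bearing group in place of a hydroxymethyl-bearing one on the same amide-type nitrogen: a 1.7-fold higher number from compound 1 to compound 3 (0.23 log units; within the scatter) and a 1.4-fold higher number from compound 2 to compound 3 (0.14 log units; within the scatter). Both lie within the scatter. On that basis no step beyond the scatter is expected in this assay for compound 4, with at most a slight drift towards a higher number as seen for compound 3, so a 1.4-fold higher number from compound 2 to compound 4 (0.14 log units; within the scatter) is the expected step.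

Compound 4 is thus expected to give about 35000 nM, within a range of 15000 nM to 80000 nM.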

Compound 4, half-maximal inhibitory concentration: > 50000 nM
Compound 4 ended at the assay's limit (the forecaster's own chance of this, stated with the estimate: 25%); middle value at least 1.4-fold (0.15 log units) away from the limit.
By their numbers in this assay, from the lowest: compounds 1, 2 and 3 (each within the scatter of the next). At a limit, above all of these: compound 4.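

In this assay compound 4 gives > 50000 nM as a limit of the assay, not a number. Read as a floor, the change gives an at least 2.4-fold higher number from compound 1 to compound 4 (0.38 log units; beyond the scatter) as the first step in the set beyond the scatter, so substituents on this amide-type nitrogen are no longer all equivalent in this read-out. The floors an at least 1.9-fold higher number from compound 2 to compound 4 (0.29 log units; that floor lies within the scatter) and an at least 1.4-fold higher number from compound 3 to compound 4 (0.14 log units; that floor lies within the scatter) stay within the scatter, so the true size of those steps, including that of carboxy in place of hydrogen on the saturated chain carbon, remains unread.

Open, as far as these compounds go, is how an amine or a longer chain ending in a single carboxylic acid would read on the same nitrogen. Also open, from the compounds shown here alone, is whether a methyl ester of the 1,2-dicarboxyethyl group would return the number to the range of compounds 1, 2 and 3.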